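A few compounds are considered here, and "the series" means these few. Any claim that something is new, unique, unknown or untested is made for them only; others in the source may bear on it.

Working notes on the series. Compound 1 `CC(C)=CCc1cc(C(=O)Nc2cc3ccc(OCCC4CCCCN4)c(C)c3oc2=O)ccc1O` gives 640 nM in a functional assay on SK-BR-3 cells (Homo sapiens) for antiproliferative activity; on this read-out lower numbers stand for stronger inhibition and higher numbers for weaker inhibition. Compound 2 `CC(C)=CCc1cc(C(=O)Nc2cc3ccc(OCC4CCCN(C)C4)c(C)c3oc2=O)ccc1O` gives 1300 nM, and compound 3 `CCN(C)CCCOc1ccc2cc(NC(=O)c3ccc(O)c(CC=C(C)C)c3)c(=O)oc2c1C` gives 730 nM. Compound 1 has the lowest number of the three; compound 3 stands nearest it and compound 2 furthest, a 2.0-fold higher number from compound 1 to compound 2 (0.31 log units; beyond the scatter). From compound 1 to compound 3 the step is a 1.1-fold higher number from compound 1 to compound 3 (0.06 log units; within the scatter), and from compound 2 to compound 3 it is a 1.8-fold lower number from compound 2 to compound 3 (0.25 log units; within the scatter).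

Compound 4 `CC(C)=CCc1cc(C(=O)Nc2cc3ccc(OCCCNC(C)C)c(C)c3oc2=O)ccc1O` is not yet measured. Its difference from compound 1: (isopropylamino)methyl in place of piperidin-2-yl on a saturated chain carbon, two bonds along the chain from an oxygen on an aromatic ring. Going by the values given here, the measured step that bears most directly on this is the one from compound 1 to compound 3, which also exchanges piperidin-2-yl for an open-chain amine on a saturated chain carbon, two bonds along the chain from an oxygen on an aromatic ring, and it read a 1.1-fold higher number from compound 1 to compound 3 (0.06 log units; within the scatter), within the scatter. The step from compound 1 to compound 2, a 2.0-fold higher number from compound 1 to compound 2 (0.31 log units; beyond the scatter), moves the ring rather than opening it and is only loosely related. In this assay no step beyond the scatter is therefore expected for compound 4. For compound 4 the expected step is a 1.2-fold higher number from compound 1 to compound 4 (0.07 log units; within the scatter). Compound 4 is estimated at 750 nM, with a range from 350 nM to 1600 nM.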

Compound 4, half-maximal inhibitory concentration: 750 nM
The estimate for compound 4 equals the measured number at the digits printed; the measured number falls inside the stated range.
By their numbers in this assay, from the lowest: compounds 1, 3, 4 and 2 (each within the scatter of the next, the first and the last beyond it).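

Replacing 2-(piperidin-2-yl)ethoxy with 3-(isopropylamino)propoxy stays within the scatter in this assay (a 1.2-fold higher number from compound 1 to compound 4 (0.07 log units; within the scatter)), so a second open-chain amine now reads like the ring at this place, and that reading no longer rests on the ethyl(methyl)amino group alone. The series also gains its first exchange of one open-chain amine for another, isopropylamino in place of ethyl(methyl)amino three bonds along the chain from an oxygen on an aromatic ring, and this too gives no change that can be read (a 1.0-fold higher number from compound 3 to compound 4 (0.01 log units; within the scatter)). The step against the 1-methylpiperidin-3-yl compound likewise stays within the scatter (a 1.7-fold lower number from compound 2 to compound 4 (0.24 log units; within the scatter)), whereas the corresponding step from the piperidin-2-yl compound lies beyond it (a 2.0-fold higher number from compound 1 to compound 2 (0.31 log units; beyond the scatter)), so the series does not separate cleanly at this place, and nothing available accounts for these readings.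

From the compounds shown here alone, how far this tolerance extends remains open, since a morpholine, a primary amine or a carboxylic acid at the chain end has no reading here. Going by these compounds, a longer chain between the oxygen and the amine, and changes elsewhere on the shared core, also remain open.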